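This account rests on a few compounds, and the source may have more. Where it says the series, first, only, none or still open, it means among the compounds named here.

Measured so far:
- compound 2 `COc1cc(Cl)cc(-c2nn(-c3cccc(NC(=O)Nc4cc(C(F)(F)F)cc(C(F)(F)F)c4)c3)cc2-c2ccncc2)c1`, in a functional assay on MDA-MB-468 cells (Homo sapiens) for inhibition, read by sulforhodamine B assay, with a stated time of 48 h (on this read-out higher numbers stand for weaker inhibition and lower numbers for stronger inhibition), compound 2 gives 340 nM
- compound 1 `O=C(Nc1cccc(-n2cc(-c3ccncc3)c(-c3cc(O)cc(Cl)c3)n2)c1)Nc1ccc(Cl)c(Cl)c1`, in this assay compound 1 gives 1710 nM

Compound 2 holds the lower of the two numbers; the gap to compound 1 lies beyond the usual scatter, so compound 2 stands as the stronger inhibitor of the pair on the half-maximal inhibitory concentration read-out.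

Compound 3 `COc1cc(Cl)cc(-c2nn(-c3cccc(NC(=O)Nc4cccc(C(F)(F)F)c4)c3)cc2-c2ccncc2)c1` is the next member. It differs from compound 2 by hydrogen in place of trifluoromethyl on an aromatic carbon. Within the data shown here, no step between measured compounds covers such a change, so there is no direct precedent. The expectation for compound 3 in this assay is a modest step toward weaker inhibition, probably somewhat beyond the scatter but well short of the distance to compound 1. Compound 3 is estimated at 750 nM, with a plausible range from 250 nM to 2500 nM. This estimate corresponds to an expected step of a 2.2-fold higher number from compound 2 to compound 3 (0.34 log units; beyond the scatter).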

Compound 3, half-maximal inhibitory concentration: 1050 nM
Beside the measured number, compound 3's estimate is 1.4-fold (0.15 log units) below it, within the range that was stated.
By their numbers in this assay, from the lowest: compound 2; then compounds 3 and 1 (each within the scatter of the next).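

In this assay, among these compounds, hydrogen in place of trifluoromethyl on an aromatic carbon, meta to a trifluoromethyl group, gives a 3.1-fold higher number from compound 2 to compound 3 (0.49 log units; beyond the scatter) and provides the first comparison that differs in one place. This modest loss is beyond the scatter, so the second trifluoromethyl group adds to inhibition in this pair, yet compound 3 with one such group still gives 1050 nM as a measurable number. Nothing on hand explains why the number moves with this change.

On these data alone, whether a nitrile, a methyl or a chlorine at this carbon would keep the number closer to that of compound 2 remains open, as does the result of replacing the remaining trifluoromethyl group with hydrogen. The hydroxy group of compound 1 and the methoxy group of compound 2 also cannot be separated, since those compounds differ in more than one place.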